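Fluoro for Methoxy: Following Compound 2 to Compound 3

The compounds below may be only part of what the source reports. "The series", "measured", "known", "first", "only" and "open" are said of these compounds alone.

Of the compounds shown here, two have so far been tested in a functional assay on OVCAR-8 cells (Homo sapiens) for inhibition, read by sulforhodamine B assay, with a stated time of 48 h; on this read-out lower numbers stand for stronger inhibition of growth and higher numbers for weaker inhibition of growth. Compound 1, `CCOC(=O)[C@H](CCC(=O)O)NC(=O)c1ccc(CNc2nc3cc(N)cc(N)c3nc2-c2ccccc2)cc1`, is recorded only as a limit of the assay, < 100000 nM. Compound 2, `COc1ccc(Sc2nc3cc(N)cc(N)c3nc2-c2ccccc2)cc1`, is likewise recorded only as a limit of the assay, < 100000 nM. Both results therefore sit at the limit of < 100000 nM in this assay, at which 2 of the 2 values shown sit, so neither compound carries a number of its own, and the two cannot be placed in any order relative to each other. Compound 2 thus stands at the limit, with nothing in the data to say how far beneath it its true potency lies.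

Compound 3, `Nc1cc(N)c2nc(-c3ccccc3)c(Sc3ccc(F)cc3)nc2c1`, has not yet been measured. It differs from compound 2 in one place: fluoro in place of methoxy on an aromatic carbon. Going by the values given here, no step between measured compounds is available to set a size for such a change, and the only anchor for compound 2 is a limit, so the expectation for compound 3 rests on little. The step from compound 2 to compound 3 is expected to be a step that the limit leaves unreadable from compound 2 to compound 3, which is no more than the usual scatter in either direction. In this assay compound 3 is expected to give about 5000 nM, within a broad range from 500 nM to 50000 nM.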

Compound 3, concentration for total growth inhibition: 34700 nM
Estimate against measurement, compound 3: 6.9-fold (0.84 log units) below; low and high end bracket the measured number.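

The result for compound 2 is only a limit of the assay, so no size can be read for the step to compound 3, fluoro in place of methoxy: the limit of < 100000 nM in this assay, at which 2 of the 3 values shown sit.

The compounds shown leave open how compound 2 and compound 3 actually compare in this assay, and so whether this replacement strengthens growth inhibition, weakens it or leaves it unchanged.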